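Ring Size on the Basic Side Chain: Compound 3

The source may report more compounds than this note shows. Statements on the series, on what has been measured and on what is new or still open speak of the compounds shown alone.

Measured compounds:
compound 1 `COc1cc2c(Oc3ccc(NC(=O)C4(c5nnc(-c6ccc(F)cc6)o5)CC4)cc3F)ccnc2cc1OCCCN1CCCC1` — 150 nM
compound 2 `COc1cc2c(Oc3ccc(NC(=O)c4cc(-c5ccc(F)cc5)on4)cc3)ccnc2cc1OCCCN1CCC(C)CC1` — 3340 nM

In a functional assay on A549 cells (Homo sapiens) for antiproliferative activity, read by MTT assay, with a stated time of 72 h (a lower number here means a stronger inhibitor, a higher number a weaker inhibitor), compound 1 gives 150 nM, the lowest of the two numbers available. Compound 2 gives 3340 nM, a gap beyond the usual scatter. Among the measured compounds shown here, no single-change step between measured compounds exists here; compound 2 differs from compound 1 in several places at once, so only its two values can be set side by side.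

Compound 3 `COc1cc2c(Oc3ccc(NC(=O)C4(c5nnc(-c6ccc(F)cc6)o5)CC4)cc3F)ccnc2cc1OCCCN1CCCCC1` differs from compound 1 in one place: piperidin-1-yl in place of pyrrolidin-1-yl on a saturated chain carbon, three bonds along the chain from an oxygen on an aromatic ring. For the measured compounds named here, there is no measured step for this kind of change to draw on. The step of a 1.1-fold higher number from compound 1 to compound 3 (0.05 log units; within the scatter) is expected to stay within the scatter, with no clear direction. Compound 3 is estimated at 170 nM, with a range from 60 nM to 480 nM.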

Compound 3, half-maximal inhibitory concentration: 53 nM
Beside the measured number, compound 3's estimate is 3.2-fold (0.51 log units) above it; the measured number lies below the stated range.
By their numbers in this assay, from the lowest: compound 3; then compound 1; then compound 2.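

In this assay the ring carried on the propyl chain turns out to matter: going from 3-(pyrrolidin-1-yl)propyl to 3-(piperidin-1-yl)propyl gives a 2.8-fold lower number from compound 1 to compound 3 (0.45 log units; beyond the scatter) and is a modest but real step, which puts the lowest number of the set on compound 3 while leaving the rest of the structure untouched. This single-change step isolates the ring at this position, which the gap between compound 1 and compound 2 could not do, since those two differ in several places at once. Nothing on hand explains the step.

On these data alone, whether the same change would carry over to the core of compound 2 stays open. So does the effect of a morpholine ring, an azepane ring or a dimethylamino group on this propyl chain, or of a longer chain carrying the piperidin-1-yl ring.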